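The source may report more compounds than this note shows. Statements on the series, on what has been measured and on what is new or still open speak of the compounds shown alone.

Compound 1 `CCC(CC)Nc1nc(OC)c(-c2ccc(Cl)cc2Cl)nc1C` gives 14.4 nM in an assay on IMR-32 cells for displacement of a labelled ligand from corticotropin-releasing factor receptor 1 (Homo sapiens), read by scintillation counting, with a stated time of 2 h; on this read-out higher numbers stand for weaker inhibition and lower numbers for stronger inhibition. Of the three measured compounds it sits in the middle of the numbers: compound 2 `CCC(CC)Nc1nc(C)c(-c2ccc(Cl)cc2Cl)nc1C`, at 27 nM, lies within the scatter of it, while compound 3 `CCc1nc(-c2ccc(OC(F)F)cc2Cl)c(OC)nc1NC(CC)CC`, at 2.5 nM, is the furthest away and beyond the scatter. Compound 4 `CCC(CC)Nc1nc(OC)c(-c2ccc(Cl)cc2Cl)nc1OC` differs from compound 1 by methoxy in place of methyl on an aromatic carbon. Going by the values given here, the only measured step that bears on this swap is a 1.9-fold higher number from compound 1 to compound 2 (0.27 log units; within the scatter), a methyl-for-methoxy exchange on another aromatic carbon of the shared core that stayed inside the scatter. On that basis the step of a 1.1-fold lower number from compound 1 to compound 4 (0.04 log units; within the scatter) is expected to stay within the scatter as well, with no clear direction. Compound 4 is therefore estimated at 13 nM, with a range from 4 nM to 45 nM.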

Compound 4, inhibition constant: 8.4 nM
For compound 4 the middle estimate is 1.5-fold (0.19 log units) above the measured one, and the stated range covers the measured number.
By their numbers in this assay, from the lowest: compound 3; then compounds 4, 1 and 2 (each within the scatter of the next, the first and the last beyond it).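

On the aromatic carbon next to the ring nitrogen, methoxy in place of methyl gives a 1.7-fold lower number from compound 1 to compound 4 (0.23 log units; within the scatter), so this exchange, now seen at this position, does not separate the two groups in this assay. Compound 4 also shows that a methoxy group here, para to the other methoxy group, keeps the number within the scatter of compound 1. Nothing available explains this result. Still open, on these data alone, is whether a larger change on this carbon, such as a dimethylamino group or a propyl chain, would move the number beyond the scatter. Compound 3 carries ethyl on this carbon but differs elsewhere too, so it cannot settle this.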